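A few compounds are considered here, and "the series" means these few. Any claim that something is new, unique, unknown or untested is made for them only; others in the source may bear on it.

Measured so far:
Compound 1, `C[C@H]1CC/C(=N\Nc2ccc(O)cc2)c2ncc(C(=O)O)c(=O)n21` — in a functional assay on the whole organism for inhibition, with Rattus norvegicus as the target (on this read-out higher numbers stand for an effect only at larger amounts of compound and lower numbers for an effect already at smaller amounts), compound 1 gives > 100 umol/kg.
Compound 2, `CCOc1ccc(N/N=C2\CC[C@H](C)n3c2ncc(C(=O)O)c3=O)cc1` — compound 2 gives > 100 umol/kg.
Compound 3, `CC1CC/C(=N\Nc2cccc(C(=O)O)c2)c2ncc(C(=O)O)c(=O)n21` — compound 3 gives > 100 umol/kg.

For compound 3 the value in this assay is a limit of the assay, not a number. For compound 1 the value is likewise a limit. For compound 2 the value is also only a limit.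

Compound 2 differs from compound 1 by ethyl in place of hydrogen on an oxygen on an aromatic ring. The step that the two limits leave unreadable from compound 1 to compound 2 cannot be sized, because the limit of > 100 umol/kg in this assay, at which 3 of the 3 values shown sit, is where every value shown sits.

Compound 4, `CCOC(=O)c1cccc(N/N=C2\CCC(C)n3c2ncc(C(=O)O)c3=O)c1`, has not yet been measured in this assay. It differs from compound 3 by ethyl in place of hydrogen on an oxygen next to a carbonyl group. The difference between the core of compound 3 and the core of compound 1 is not broken down here. Among the measured compounds shown here, the change from compound 3 to compound 4 is the same kind of change as the one from compound 1 to compound 2, but not the same: in the first the oxygen sits on an aromatic ring whose other neighbours are aromatic carbon, in the second it sits next to a carbonyl group whose other neighbours are carbonyl carbon.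

For the measured compounds named here, with every value so far at the limit and the earlier step unreadable, the expected step is a step that the limit leaves unreadable from compound 3 to compound 4, with little to support a number. Compound 4 is estimated at 150 umol/kg, most probably again reported only as a limit.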

Compound 4, dose for 50% inhibition: > 100 umol/kg
Compound 4 ended at the assay's limit; the forecaster's own chance of this, stated with the estimate: 80%; the middle value is on the limit's open side.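

In this assay compound 4 gives > 100 umol/kg, which is a limit and not a number. No step from compound 3 to compound 4 can be read, because neither compound has a value that can be sized: the limit of > 100 umol/kg in this assay, at which 4 of the 4 values shown sit.

The compounds shown leave open how any of them ranks against another, and whether going from carboxy to ethoxycarbonyl changes the effect at all.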